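A few compounds are considered here, and "the series" means these few. Any claim that something is new, unique, unknown or untested is made for them only; others in the source may bear on it.

Measured so far in a functional assay on HCT-116 cells (Homo sapiens) for antiproliferative activity, read by WST assay, with a stated time of 72 h (a higher number here means that more compound is needed for the effect, a lower number that less compound is needed), are two compounds:
Compound 1 (`CCCCNCC(=O)Nc1ccc(/C(N)=N/O)cc1`) gives 83000 nM
Compound 2 (`CCCCNCCCC(=O)Nc1ccc(/C(N)=N/O)cc1`) gives 267000 nM

Going by the values given here, compound 2 holds the higher of these two numbers, and compound 1 is its only neighbour. Compound 3 (`CCCCNCCC(=O)Nc1ccc(/C(N)=N/O)cc1`) differs from compound 2 in one place (butylamino in place of (butylamino)methyl on a saturated chain carbon, two bonds along the chain from a carbonyl carbon): butylamino in place of (butylamino)methyl on a saturated chain carbon, two bonds along the chain from a carbonyl carbon.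

Among the compounds with values here, one measured step bears on this change (a 3.2-fold higher number from compound 1 to compound 2 (0.51 log units; beyond the scatter)), modest in size and made on the same chain. Compound 3 sits structurally between the pair, so the move from compound 2 should retrace part of that step. Two compounds establish no trend, however, and a smaller shift towards a lower number is only an expectation, perhaps one that stays within the scatter. The expected step is a 1.8-fold lower number from compound 2 to compound 3 (0.25 log units; within the scatter) (an estimate). For compound 3 the estimated value is 150000 nM (expected range 70000 nM to 300000 nM).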

Compound 3, half-maximal effective concentration: 153000 nM
Estimate against measurement, compound 3: 1.0-fold (0.01 log units) below; the range from low to high includes it.
By their numbers in this assay, from the lowest: compounds 1, 3 and 2 (each within the scatter of the next, the first and the last beyond it).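

In this assay butylamino in place of (butylamino)methyl at this position gives a 1.7-fold lower number from compound 2 to compound 3 (0.24 log units; within the scatter) and, on the other side, the series shows a 1.8-fold higher number from compound 1 to compound 3 (0.27 log units; within the scatter), so compound 3 cannot be told apart from either neighbour. Only the two outer members remain separated, by a 3.2-fold higher number from compound 1 to compound 2 (0.51 log units; beyond the scatter), and across these three compounds the chain length therefore resolves only at its extremes. Nothing available explains why the outer pair differs.

The compounds shown leave open whether a longer chain than 2-(butylamino)ethyl would continue the same direction, since only three lengths are covered. They also leave open whether the butyl group matters at all, as a tertiary amine or a carboxylic acid in place of the butylamino nitrogen does not appear among them.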